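Swapping Methoxy for Nitro at the High End

This account rests on a few compounds, and the source may have more. Where it says the series, first, only, none or still open, it means among the compounds named here.

In a functional assay (mast cells) for inhibition, with Rattus norvegicus as the target (a lower number here means that less compound is needed, a higher number that more compound is needed for the effect), compound 1 (`CC1CC/C(=N\Nc2cccc(Br)c2)c2ncc(C(=O)O)c(=O)n21`) gives 6700 nM and compound 2 (`COc1ccc(N/N=C2\CCC(C)n3c2ncc(C(=O)O)c3=O)cc1`) gives 128000 nM as the higher of the two numbers. Going by the values given here, the only measured step (a 19-fold higher number from compound 1 to compound 2 (1.28 log units; beyond the scatter)) is large and shows that swapping the aromatic group can shift the number strongly, with the methoxy compound on the high side. Compound 3 (`CC1CC/C(=N\Nc2ccc([N+](=O)[O-])cc2)c2ncc(C(=O)O)c(=O)n21`) has nitro in place of methoxy on an aromatic carbon. Among the compounds with values here, no measured compound carries nitro, so the estimated step is expected to be a smaller one toward a lower number (a 4.3-fold lower number from compound 2 to compound 3 (0.63 log units; beyond the scatter)). Compound 3 is estimated at 30000 nM with an expected range from 6000 nM to 150000 nM in this test.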

Compound 3, half-maximal effective concentration: 8900 nM
Beside the measured number, compound 3's estimate is 3.4-fold (0.53 log units) above it; the measured number falls inside the stated range.
By their numbers in this assay, from the lowest: compounds 1 and 3 (each within the scatter of the next); then compound 2.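

In this assay nitro in place of methoxy, on the aromatic carbon para to a large group, gives (a 14-fold lower number from compound 2 to compound 3 (1.16 log units; beyond the scatter)). A group at this place therefore does not by itself bring the high number of compound 2: with nitro there, compound 3 lies within the scatter of compound 1. No available evidence explains the size of this step.

Going by these compounds alone, only two groups at this place can be compared directly, so they give no trend. On these data alone, how an amine or a chlorine atom here would fit remains open.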